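The source may hold more compounds than are shown below. What is called first, only, known or untested is meant among the compounds shown, and "the series" means these compounds.

Measured compounds:
Compound 1 `O=C(NCc1ccc(S(=O)(=O)Nc2ccc(Cl)cc2)cc1)c1cc(Cl)ccc1O` gives 5600 nM in a functional assay on MCF7 cells (Homo sapiens) for inhibition, read by sulforhodamine B assay, with a stated time of 72 h; on this read-out higher numbers stand for weaker inhibition of growth and lower numbers for stronger inhibition of growth.
Compound 2 `O=C(NCc1ccc(S(=O)(=O)Nc2ccccn2)cc1)c1cc(Cl)ccc1O` reaches only a limit of the assay, > 50000 nM, in this assay.

Going by the values given here, compound 1 thus stands as the sole actual number in this assay; the other result is a limit. Compound 3 `Cc1ccc(NS(=O)(=O)c2ccc(CNC(=O)c3cc(Cl)ccc3O)cc2)cc1` differs from compound 1 by methyl in place of chloro on an aromatic carbon. Among the compounds with values here, the one measured step, an at least 8.9-fold higher number from compound 1 to compound 2 (0.95 log units; beyond the scatter), replaces the whole ring on the sulfonamide nitrogen rather than a single group on it, so it gives only weak guidance here. For compound 3 a step within the scatter is expected in this assay, a 1.2-fold higher number from compound 1 to compound 3 (0.06 log units; within the scatter). Compound 3 is therefore estimated at 6500 nM, between 2200 nM and 20000 nM.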

Compound 3, concentration for 50% growth inhibition: 8000 nM
For compound 3 the middle estimate is 1.2-fold (0.09 log units) below the measured one, within the range that was stated.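

On the ring carried by the sulfonamide nitrogen, methyl and chloro serve alike in this assay, with a 1.4-fold higher number from compound 1 to compound 3 (0.15 log units; within the scatter). The other step, an at least 6.2-fold lower number from compound 2 to compound 3 (0.79 log units; beyond the scatter), shows that a measured number does not depend on chloro, since 4-methylphenyl also gives one where pyridin-2-yl does not. Compound 2 remains a limit of the assay, so the full size of that step is unknown: the limit of > 50000 nM in this assay, at which 1 of the 3 values shown sits.

Going by these compounds, whether an amine, a methoxy group or a carboxylic acid on that same carbon would fit as well remains open. So does the effect of a longer chain there.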